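This account rests on a few compounds, and the source may have more. Where it says the series, first, only, none or still open, it means among the compounds named here.

The measured compounds in an assay for inhibition of Fatty-acid amide hydrolase 1 (Rattus norvegicus); on this read-out lower numbers stand for stronger inhibition and higher numbers for weaker inhibition:

compound 1, `COC(=O)c1ccc(-c2cnc(C(=O)CCc3ccc(-c4ccccc4)cc3)o2)nc1`, giving 2.2 nM
compound 2, `NC(=O)c1cccc(-c2cnc(C(=O)CCc3ccc(-c4ccccc4)cc3)o2)n1`, giving 1.2 nM
compound 3, `O=C(CCc1ccc(-c2ccccc2)cc1)c1ncc(C(=O)C(F)(F)F)o1`, giving 8 nM

Compound 3 stands highest of the three numbers shown in this assay. Its nearest neighbour is compound 1, reached by the step of a 3.6-fold higher number from compound 1 to compound 3 (0.56 log units; beyond the scatter), and its furthest is compound 2, reached by the step of a 6.7-fold higher number from compound 2 to compound 3 (0.82 log units; beyond the scatter); both of these steps lie beyond the scatter, so compound 3 is the weakest inhibitor among the three. The difference between compound 1 and compound 2 is the step of a 1.8-fold lower number from compound 1 to compound 2 (0.26 log units; within the scatter), which lies within the scatter.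

The unmeasured compound 4 is `O=C(O)c1ccc(-c2cnc(C(=O)CCc3ccc(-c4ccccc4)cc3)o2)cn1`. It differs from compound 3 by 6-carboxypyridin-3-yl in place of (trifluoromethyl)carbonyl on an aromatic carbon. This change runs against the direction of the two steps into compound 3: in both of those, a substituted pyridyl group on the shared core was replaced by (trifluoromethyl)carbonyl and the number rose. Compound 4 restores a substituted pyridyl group at that place, so the number is expected to fall, by a step of about the size seen in a 3.6-fold higher number from compound 1 to compound 3 (0.56 log units; beyond the scatter) and a 6.7-fold higher number from compound 2 to compound 3 (0.82 log units; beyond the scatter), which is the expected step of a 3.2-fold lower number from compound 3 to compound 4 (0.51 log units; beyond the scatter). Compound 4 is therefore estimated at 2.5 nM, within a range from 0.8 nM to 10 nM.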

Compound 4, inhibition constant: 44 nM
Beside the measured number, compound 4's estimate is 18-fold (1.25 log units) below it; measured number outside the range, above it.
By their numbers in this assay, from the lowest: compounds 2 and 1 (each within the scatter of the next); then compound 3; then compound 4.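

In this assay, going by these compounds alone, a substituted pyridyl group at this place, on an aromatic carbon next to the ring oxygen, does not by itself give a lower number than (trifluoromethyl)carbonyl: the earlier compounds showed only pyridyl groups on the low side of compound 3, whereas 6-carboxypyridin-3-yl gives a 5.5-fold higher number from compound 3 to compound 4 (0.74 log units; beyond the scatter) in the opposite direction. Within the data shown here, the choice of pyridyl group also matters far more than the earlier compounds showed, since a 20-fold higher number from compound 1 to compound 4 (1.30 log units; beyond the scatter) and a 37-fold higher number from compound 2 to compound 4 (1.56 log units; beyond the scatter) are both large, while the only earlier step between pyridyl groups, a 1.8-fold lower number from compound 1 to compound 2 (0.26 log units; within the scatter), lies within the scatter. No measurement at hand offers an explanation for this reversal.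

Compound 4 differs from compound 1 and compound 2 both in its carboxylic acid and in the pyridin-3-yl attachment, so the compounds shown leave open which of the two goes with the higher number, a question that a 6-carboxypyridin-2-yl group or a 6-(methoxycarbonyl)pyridin-3-yl group at this place would separate. They also leave open whether an unsubstituted pyridin-3-yl group, or one carrying an amine in place of the carboxylic acid, would return the number to the level of compound 1.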